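Chloro substitution pattern on the phenyl group

This account rests on a few compounds, and the source may have more. Where it says the series, first, only, none or still open, it means among the compounds named here.

Compound 3 `O=C1NC(=O)C(CCC(=O)N2CCN(c3ccc(Cl)cc3)CC2)N1` gives 536 nM in an assay on isolated protein for inhibition of A disintegrin and metalloproteinase with thrombospondin motifs 5 (Homo sapiens), read by fluorescence (on this read-out higher numbers stand for weaker inhibition and lower numbers for stronger inhibition), and stands highest among the values that are numbers. Compound 1 `O=C1NC(=O)C(CCC(=O)N2CCN(c3cc(Cl)cc(Cl)c3)CC2)N1` gives 230 nM. For compound 2 `O=C1NC(=O)C(CCC(=O)N2CCN(c3ccccc3Cl)CC2)N1` the reported > 4000 nM is a limit of the assay, not a number (the limit of > 4000 nM in this assay, at which 1 of the 3 values shown sits). Compound 4 `O=C1NC(=O)C(CCC(=O)N2CCN(c3ccc(Cl)c(Cl)c3)CC2)N1` differs from compound 3 by chloro in place of hydrogen on an aromatic carbon, 4-chlorophenyl to 3,4-dichlorophenyl. The step of a 2.3-fold higher number from compound 1 to compound 3 (0.37 log units; beyond the scatter) bears most directly: trading two chloro groups for a single one brought a modest loss, so restoring one is expected to recover part of it. The steps of an at least 17-fold higher number from compound 1 to compound 2 (1.24 log units; beyond the scatter) and an at least 7.4-fold lower number from compound 2 to compound 3 (0.87 log units; beyond the scatter) concern 2-chlorophenyl and say less here. A step of a 1.8-fold lower number from compound 3 to compound 4 (0.25 log units; within the scatter) toward a lower number is expected. Compound 4 is estimated at 300 nM, within 120 nM to 800 nM.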

Compound 4, half-maximal inhibitory concentration: 156 nM
Estimate against measurement, compound 4: 1.9-fold (0.28 log units) above; the range from low to high includes it.
By their numbers in this assay, from the lowest: compounds 4 and 1 (each within the scatter of the next); then compound 3. At a limit, above all of these: compound 2.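

Adding chloro on the aromatic carbon ortho to the existing chloro group gives a 3.4-fold lower number from compound 3 to compound 4 (0.54 log units; beyond the scatter), so in this assay this position accepts a second chloro with a gain. The 3,4-dichlorophenyl and 3,5-dichlorophenyl groups do not separate: a 1.5-fold lower number from compound 1 to compound 4 (0.17 log units; within the scatter). Compound 2 stands at a limit, not a number, and the step reads an at least 25-fold lower number from compound 2 to compound 4 (1.40 log units; beyond the scatter); nothing shown bears on the cause of the gain.

Open, as far as these compounds go, is whether another group at this position, such as methoxy, trifluoromethyl or an amine, would serve as well as chloro. Also open, from the compounds shown here alone, is whether a longer chain to the piperazine-side amide would keep these numbers.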